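Carbamate ester change on compound 2

The source may hold more compounds than are shown below. What is called first, only, known or untested is meant among the compounds shown, and "the series" means these compounds.

Compound 1 `CC(C)(C)OC(=O)N1CCC(O[C@H]2CC[C@H](Oc3ccc(S(C)(=O)=O)cc3)CC2)CC1` carries a 4-(methylsulfonyl)phenyl group on an oxygen on a saturated carbon; in a functional assay on isolated protein for agonist activity at Glucose-dependent insulinotropic receptor (Homo sapiens), read by HTRF and cAMP accumulation (a lower number here means that less compound is needed, a higher number that more compound is needed for the effect), compound 1 gives 16.1 nM. Compound 2 `CC(C)(C)OC(=O)N1CCC(O[C@H]2CC[C@H](Oc3cnc(S(C)(=O)=O)cn3)CC2)CC1` has 5-(methylsulfonyl)pyrazin-2-yl in that place, and in this assay compound 2 gives 5.9 nM. Compound 3 `CC(C)(C)OC(=O)N1CCC(O[C@H]2CC[C@H](Oc3cnc(C#N)cn3)CC2)CC1` has 5-cyanopyrazin-2-yl there, and in this assay compound 3 gives 8.3 nM. The step of a 2.7-fold lower number from compound 1 to compound 2 (0.44 log units; beyond the scatter) is the only one beyond the scatter, whereas a 1.9-fold lower number from compound 1 to compound 3 (0.29 log units; within the scatter) and a 1.4-fold higher number from compound 2 to compound 3 (0.15 log units; within the scatter) stay within it. Compound 2 thus holds the lowest of the three numbers, but its gap to compound 3 lies within the scatter, so no order between those two is claimed.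

Compound 4 `CS(=O)(=O)c1cnc(O[C@H]2CC[C@H](OC3CCN(C(=O)OC4CCOC4)CC3)CC2)cn1` keeps the whole of compound 2 except at one place, where (oxolan-3-yl in place of tert-butyl on an oxygen next to a carbonyl group). Among the compounds with values here, all three measured steps vary the aryl group on the oxygen on a saturated carbon; none touches the oxygen next to a carbonyl group, so no measured step bears directly on this change. With nothing in the series pointing either way, a step no larger than the usual scatter is expected, in either direction. The estimate for compound 4 in this assay is 7 nM, with a range from 3 nM to 18 nM. This corresponds to an expected step of a 1.2-fold higher number from compound 2 to compound 4 (0.07 log units; within the scatter).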

Compound 4, half-maximal effective concentration: 427 nM
The estimate for compound 4 lay 61-fold (1.79 log units) below the measured number, and the stated range ends below it.
By their numbers in this assay, from the lowest: compounds 2, 3 and 1 (each within the scatter of the next, the first and the last beyond it); then compound 4.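

The carbamate ester position, which none of the earlier aryl changes touched, proves far less tolerant in this assay than the aryl position: oxolan-3-yl in place of tert-butyl on an oxygen next to a carbonyl group gives a 72-fold higher number from compound 2 to compound 4 (1.86 log units; beyond the scatter). This exceeds the largest step among the earlier compounds, a 2.7-fold lower number from compound 1 to compound 2 (0.44 log units; beyond the scatter), so in this series the tert-butyl carbamate matters more to the number than the choice among the aryl groups shown. No supporting measurement is available that accounts for the size of this step.

The change exchanges a ring-free group for a five-membered non-aromatic ring with one hetero atom, adding one hydrogen-bond acceptor, and the compounds shown cannot separate the contribution of the ring from that of its oxygen; a cyclopentyl or isopropyl carbamate would help to tell these apart. Also open, as far as these compounds go, is whether the same step holds on the 5-cyanopyrazin-2-yl group of compound 3 or the 4-(methylsulfonyl)phenyl group of compound 1, since the ester has been varied only on the 5-(methylsulfonyl)pyrazin-2-yl group of compound 2.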